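This account rests on a few compounds, and the source may have more. Where it says the series, first, only, none or still open, it means among the compounds named here.

Of the compounds shown here, three of one series have been tested in an ADME assay on L6 cells (Rattus norvegicus) for cytotoxicity; a higher number here means a weaker inhibitor, a lower number a stronger inhibitor. Compound 1 `CC(C)NC(=N)c1ccc(-c2cc3cc(C(=N)NC(C)C)ccc3o2)cc1` gives > 198000 nM, which is a limit of the assay rather than a number. Compound 3 `CC(C)NC(=N)c1ccc(-c2cc3cc(C(=N)NC(C)C)cc(O)c3o2)cc1` gives > 185000 nM, likewise a limit. Compound 3 differs from compound 1 by hydroxy in place of hydrogen on an aromatic carbon, and the resulting step is a step that the two limits leave unreadable from compound 1 to compound 3, because both values rest on limits, namely the limit of > 198000 nM in this assay, at which 1 of the 3 values shown sits, and (the limit of > 185000 nM in this assay, at which 1 of the 3 values shown sits). Among the compounds with values here, compound 2 `N=C(N)c1ccc(-c2cc3cc(C(=N)N)cc(O)c3o2)cc1` gives 184000 nM, the only plain number among the three. How the core of compound 2 differs from the core of compound 1 is not broken down here.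

Compound 4 `N=C(N)c1ccc(-c2cc3cc(C(=N)N)cc(O)c3o2)c(O)c1` has not yet been measured in this assay. It differs from compound 2 by hydroxy in place of hydrogen on an aromatic carbon, the same kind of change as that from compound 1 to compound 3, though the surroundings differ: in compound 3 the hydroxy sits ortho to a fused ring, meta to a fused ring and meta to a group of 6 heavy atoms, whereas in compound 4 it sits ortho to a large group and meta to a group of 3 heavy atoms. For compound 4 the expected step is a 1.0-fold higher number from compound 2 to compound 4 (0.01 log units; within the scatter), since compound 2 gives 184000 nM. The earlier change of this kind left compound 3 at a limit. Compound 4 is therefore estimated at 190000 nM, within a range from 110000 nM to 400000 nM, with a fair chance that only a limit is reported.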

Compound 4, half-maximal inhibitory concentration: 2100 nM
For compound 4 the middle estimate is 90-fold (1.96 log units) above the measured one, and the stated range ends above it.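

In this assay, hydroxy in place of hydrogen, ortho to a large group, gives an 88-fold lower number from compound 2 to compound 4 (1.94 log units; beyond the scatter), so on this core one small change turns compound 2 into a far stronger inhibitor. The same kind of change from compound 1 to compound 3 cannot be read, since compound 3 stands only at a limit of the assay: the limit of > 185000 nM in this assay, at which 1 of the 4 values shown sits. The data therefore do not show that so large a step carries over from one core to another, and with the hydroxy in different surroundings in compound 3 and compound 4, this single step sets no rule for the series.

The compounds shown leave open whether another group in the place of that hydroxy, such as methoxy, an amine or a fluorine atom, would give a similar number. They also leave open whether a hydroxy at that same place on the core of compound 3 would shift the number as far.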